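The source may report more compounds than this note shows. Statements on the series, on what has been measured and on what is new or still open speak of the compounds shown alone.

Measured so far: compound 1 `Cc1nnc(SCC(=O)N/N=c2/scc(-c3ccc(Cl)cc3)n2-c2ccccc2)s1` with 28 ug/mL in a functional assay on C6 cells (Rattus norvegicus) for cytotoxicity, read by MTT assay, with a stated time of 24 h; on this read-out lower numbers stand for stronger inhibition and higher numbers for weaker inhibition; compound 2 `COc1ccc(-c2cs/c(=N/NC(=O)CSc3nnnn3C)n2-c2ccccc2)cc1`, for which the entry in this assay reads "not determined" (no result reported).

Among the compounds with values here, compound 2 therefore has no number to stand on in this assay; the only measured anchor is compound 1, which shares the thiadiazolylsulfanyl chain of the planned analogue but carries a different aryl group. Compound 3 `COc1ccc(-c2cs/c(=N/NC(=O)CSc3nnc(C)s3)n2-c2ccccc2)cc1` is compound 2 with one change: 5-methyl-1,3,4-thiadiazol-2-yl in place of 1-methyl-1H-tetrazol-5-yl on a sulfur. Within the data shown here, with no measured step to lean on, the expectation for this change can only be modest: a shift, if any, of about the size of the usual scatter, in no firm direction. Because compound 1 gives 28 ug/mL with the same sulfur-linked thiadiazole, compound 3 is expected to land near that figure, with an estimated value of 30 ug/mL and a plausible range from 10 ug/mL to 90 ug/mL.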

Compound 3, half-maximal inhibitory concentration: 18.7 ug/mL
For compound 3 the middle estimate is 1.6-fold (0.21 log units) above the measured one; the range from low to high includes it.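

In this assay the 5-methyl-1,3,4-thiadiazol-2-yl group on the sulfur now appears in a second measured compound, and the two measured compounds differ in one place only: methoxy in place of chloro on an aromatic carbon. That swap gives a 1.5-fold lower number from compound 1 to compound 3 (0.18 log units; within the scatter), so with this sulfur-linked thiadiazole in place, the read-out does not tell the two groups apart. Compound 2 has no result, so the exchange of 1-methyl-1H-tetrazol-5-yl for 5-methyl-1,3,4-thiadiazol-2-yl cannot be read. Nothing measured here offers an explanation for these numbers.

From the compounds shown here alone, whether a compound carrying 1-methyl-1H-tetrazol-5-yl on the sulfur would give a number close to these remains open. Also open, going by these compounds, is what an amine or a carboxylic acid on that aromatic carbon would do to the number.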